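Aryl swap on the ring nitrogen of compound 2

The source may report more compounds than this note shows. Statements on the series, on what has been measured and on what is new or still open speak of the compounds shown alone.

In a functional assay on HOS-TE85 cells (Homo sapiens) for inhibition, read by CCK-8 assay, with a stated time of 72 h (a higher number here means a weaker inhibitor, a lower number a stronger inhibitor), compound 1 `COc1ccccc1N1C(=O)CSC1c1cccc(C(=O)NCCCCc2ccc(Cl)cc2)c1` gives 78.6 nM, compound 2 `COc1ccccc1N1C(=O)CSC1c1cccc(C(=O)NCCCCn2cccn2)c1` gives 91.7 nM and compound 3 `C#Cc1cccc(N2C(=O)CSC2c2cccc(C(=O)NCCCCc3ccccc3)c2)c1` gives 149 nM; compound 2 holds the second highest of the three numbers, though within the scatter of both others. For the measured compounds named here, the only single-point step, a 1.2-fold higher number from compound 1 to compound 2 (0.07 log units; within the scatter), concerns the chain terminus, not the ring nitrogen. Compound 4 `O=C(NCCCCn1cccn1)c1cccc(C2SCC(=O)N2c2ccncc2)c1` differs from compound 2 at that nitrogen: pyridin-4-yl in place of 2-methoxyphenyl on an amide-type nitrogen in a ring. Compound 3 also carries a different aryl there, but differs from compound 1 in two places, so the two values show only that both lie close together. Going by the values given here, no measured step bears directly on this change, so the expected step of a 1.6-fold higher number from compound 2 to compound 4 (0.21 log units; within the scatter) is small and of uncertain direction. Compound 4 is estimated at 150 nM, range 50 nM to 450 nM.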

Compound 4, half-maximal inhibitory concentration: > 1000 nM
Compound 4: only a limit was reported; the forecaster's own chance of this, stated with the estimate: 5%; middle value at least 6.6-fold (0.82 log units) from the limit.
By their numbers in this assay, from the lowest: compounds 1, 2 and 3 (each within the scatter of the next). At a limit, above all of these: compound 4.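

The aryl group on the amide-type nitrogen in the ring is not a tolerant position: pyridin-4-yl in place of 2-methoxyphenyl gives an at least 10-fold higher number from compound 2 to compound 4 (1.03 log units; beyond the scatter). The change at the chain terminus, by contrast, gives only a 1.2-fold higher number from compound 1 to compound 2 (0.07 log units; within the scatter), so the series responds far more to this aryl swap than to that one. For compound 4 the reading is a limit, not a number: the limit of > 1000 nM in this assay, at which 1 of the 4 values shown sits.

Open, from the compounds shown here alone, is whether the drop follows the pyridine ring nitrogen or the departure of the methoxy group. A plain phenyl on the same nitrogen would separate the two.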